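Triazolyl for methylpyrazolyl at the benzylic aryl group

This account rests on a few compounds, and the source may have more. Where it says the series, first, only, none or still open, it means among the compounds named here.

Compound 1 `Cc1cc(C)c(NC(=O)N(Cc2ccc(-c3ccccn3)cc2)C2CCCCCC2)c(C)c1` reaches only the assay limit of > 1 mg/kg in a functional assay on a cell-free system (plasma) with sterol O-acyltransferase, Soat (Rattus norvegicus) as the target; on this read-out lower numbers stand for an effect already at smaller amounts and higher numbers for an effect only at larger amounts of compound (the limit of > 1 mg/kg in this assay, at which 1 of the 2 values shown sits). For the measured compounds named here, compound 2 `Cc1cc(C)c(NC(=O)N(Cc2ccc(-c3cnn(C)c3)cc2)C2CCCCCC2)c(C)c1` gives 0.31 mg/kg in this assay, the only number so far. The step of an at least 3.2-fold lower number from compound 1 to compound 2 (0.50 log units; beyond the scatter) was beyond the scatter. Compound 3 `Cc1cc(C)c(NC(=O)N(Cc2ccc(-n3cncn3)cc2)C2CCCCCC2)c(C)c1` carries 1H-1,2,4-triazol-1-yl in place of 1-methyl-1H-pyrazol-4-yl on an aromatic carbon. No measured step covers this change; the one step shown swapped a six-membered for a five-membered heteroaryl, which offers no direct guide. A change within the scatter is expected for this assay. Compound 3 is estimated at 0.45 mg/kg (range 0.15 mg/kg to 1.5 mg/kg). The expected step is a 1.5-fold higher number from compound 2 to compound 3 (0.16 log units; within the scatter).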

Compound 3, dose for half-maximal effect: > 1 mg/kg
Compound 3: only a limit was reported; the forecaster's own chance of this, stated with the estimate: 30%; middle value at least 2.2-fold (0.34 log units) away from the limit.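

Replacing 1-methyl-1H-pyrazol-4-yl with 1H-1,2,4-triazol-1-yl on this aromatic carbon gives an at least 3.2-fold higher number from compound 2 to compound 3 (0.50 log units; beyond the scatter) in this assay, so a five-membered aromatic ring here does not by itself preserve the number seen for compound 2. The step between compound 1 and compound 3 cannot be read. Compound 2 remains the only one of the three with a number rather than a limit: the limit of > 1 mg/kg in this assay, at which 2 of the 3 values shown sit.

On these data alone, what an unsubstituted 1H-pyrazol-4-yl or a 1-ethyl-1H-pyrazol-4-yl would give at this carbon remains open. So does the order of compound 1 and compound 3 beyond the limit.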